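This account rests on a few compounds, and the source may have more. Where it says the series, first, only, none or still open, it means among the compounds named here.

Compound 1 `Cc1ccc(-c2c3c(nc(C)c2[C@H](OC(C)(C)C)C(=O)O)CCN(c2ccccc2)C3)cc1`: in an ADME assay on MT2 cells (Homo sapiens) for cytotoxicity, read by XTT assay, with a stated time of 4 days (on this read-out lower numbers stand for higher toxicity in this test and higher numbers for lower toxicity in this test), compound 1 gives > 40000 nM, a limit of the assay rather than a number.
Compound 2 `CC(=O)N1CCc2nc(C)c(C(OC(C)(C)C)C(=O)O)c(-c3ccc(C)cc3)c2C1`: in this assay compound 2 gives > 40000 nM, likewise a limit.
Compound 3 `Cc1nc2c(c(-c3cc(F)c4c(c3C)CCCO4)c1[C@H](OC(C)(C)C)C(=O)O)CN(CCCc1ccc(F)cc1)CC2`: in this assay compound 3 gives > 40000 nM, again a limit.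

Compound 3 thus stands where every measured compound here stands, at the limit of > 40000 nM in this assay, at which 3 of the 3 values shown sit. Among the measured compounds shown here, no value in this set is a number, so no step between measured compounds can be drawn. Compound 4 `Cc1nc2c(c(-c3cc(F)c4c(c3C)CCCO4)c1[C@H](OC(C)(C)C)C(=O)O)CN(CCCc1ccccc1F)CC2` differs from compound 3 in one place: 2-fluorophenyl in place of 4-fluorophenyl on a saturated chain carbon, three bonds along the chain from an amine nitrogen in a ring. Because all three measured values sit at the limit of > 40000 nM in this assay, at which 3 of the 3 values shown sit, no step beyond the scatter in this assay is expected. The expected step is a step that the limit leaves unreadable from compound 3 to compound 4, leaving the limit in place. Compound 4 is thus estimated at 60000 nM, with a range from 30000 nM to 200000 nM.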

Compound 4, half-maximal cytotoxic concentration: > 40000 nM
Compound 4 ended at the assay's limit (the forecaster's own chance of this, stated with the estimate: 85%); the middle value lies beyond the limit too.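

Among the compounds shown here, no step from compound 3 to compound 4 can be read, and both compounds sit at the assay's limit: the limit of > 40000 nM in this assay, at which 4 of the 4 values shown sit. The compounds shown leave open where the true half-maximal cytotoxic concentration of any of them lies in this assay.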